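This account rests on a few compounds, and the source may have more. Where it says the series, first, only, none or still open, it means among the compounds named here.

Compound 1 `CC(C)N(Cc1cccc(OCCCCCC(=O)O)c1)C(=O)c1ccccc1` stands only at a limit in an ADME assay on BJ cells (Homo sapiens) for cytotoxicity, read by CellTiter-Glo and resazurin assay, with a stated time of 72 h; a lower number here means that less compound is needed, a higher number that more compound is needed for the effect: compound 1 gives > 26000 nM, which is a limit of the assay rather than a number. The two other values shown are limits as well. Compound 2 `CC(C)N(Cc1cccc(OCCCCCC(=O)O)c1)C(=O)c1ccc(-c2cccc3ccccc23)cc1` gives < 1.3 nM, a limit. Compound 3 `COc1cccc(-c2ccc(C(=O)N(Cc3cccc(OCCCCCC(=O)O)c3)C(C)C)cc2)c1` gives > 20900 nM, also a limit. Adding naphthalen-1-yl brought an at least 20000-fold lower number from compound 1 to compound 2 (4.30 log units; beyond the scatter), whereas the 3-methoxyphenyl change left a step that the two limits leave unreadable from compound 1 to compound 3, and between the two an at least 16000-fold higher number from compound 2 to compound 3 (4.20 log units; beyond the scatter). Compound 4 `CC(C)N(Cc1cccc(OCCCCCC(=O)O)c1)C(=O)c1ccc(-c2c[nH]c3ccccc23)cc1` differs from compound 1 by 1H-indol-3-yl in place of hydrogen on an aromatic carbon. Only the naphthalen-1-yl step resembles this change, so the expected and estimated outcome in this assay is an at least 86-fold lower number from compound 1 to compound 4 (1.93 log units; beyond the scatter) with wide uncertainty. Compound 4 is therefore estimated at 300 nM, within 3 nM to 20000 nM.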

Compound 4, half-maximal effective concentration: > 26000 nM
Compound 4 was reported as a limit (the forecaster's own chance of this, stated with the estimate: 40%); middle value at least 86-fold (1.93 log units) from the limit.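

Putting 1H-indol-3-yl in place of naphthalen-1-yl brought an at least 20000-fold higher number from compound 2 to compound 4 (4.30 log units; beyond the scatter). Two aromatic rings at this place, para to a large group, therefore do not by themselves give the low number of compound 2 in this assay. The steps from compound 1 and from compound 3 to compound 4 cannot be read, since each joins two limits. Still open, from the compounds shown here alone, is whether an amine or a hydroxyl group on the naphthalen-1-yl group would keep that low number. Going by these compounds, the true value of compound 2, known only as a limit, also remains open.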